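Swapping phenyl for bromo on two different cores

The source may report more compounds than this note shows. Statements on the series, on what has been measured and on what is new or still open speak of the compounds shown alone.

Three compounds have been measured in an ADME assay on HEK-293T cells (Homo sapiens) for cytotoxicity, read by luminescence and CellTiter-Glo, with a stated time of 24 h; on this read-out higher numbers stand for lower toxicity in this test and lower numbers for higher toxicity in this test:
Compound 1 `CCCNC(=O)[C@@H]1C[C@H]2CCC[C@@H](C1)[C@@H]2NC(=O)c1cc2sc(-c3ccccc3)nc2n1Cc1ccc(OC)cc1` gives > 100000 nM, which is a limit of the assay, not a number.
Compound 2 `CCCNC(=O)[C@@H]1C[C@H]2CCC[C@@H](C1)[C@@H]2NC(=O)c1cc2sc(Br)nc2n1Cc1ccc(OC)cc1` gives > 100000 nM, also a limit.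
Among the measured compounds shown here, compound 3 `CCCNC(=O)C1CCN(C(=O)c2cc3sc(-c4ccccc4)nc3n2Cc2ccc(OC)cc2)CC1` gives 22900 nM, the only plain number among the three.

Compound 1 and compound 2 differ by bromo in place of phenyl on an aromatic carbon. Because (the limit of > 100000 nM in this assay, at which 2 of the 3 values shown sit), the step from compound 1 to compound 2 comes out as a step that the two limits leave unreadable from compound 1 to compound 2. The core of compound 3 differs from the core of compound 1 in a way that is not broken down here. Compound 4 `CCCNC(=O)C1CCN(C(=O)c2cc3sc(Br)nc3n2Cc2ccc(OC)cc2)CC1` carries the same change on the core of compound 3: bromo in place of phenyl on an aromatic carbon. With the earlier step unreadable, the step from compound 3 to compound 4 is expected to be a 1.3-fold higher number from compound 3 to compound 4 (0.12 log units; within the scatter). Compound 4 is estimated at 30000 nM, with a likely range from 10000 nM to 100000 nM.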

Compound 4, half-maximal cytotoxic concentration: 36700 nM
The estimate for compound 4 lay 1.2-fold (0.09 log units) below the measured number; measured number inside the range.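

In this assay bromo in place of phenyl on the core of compound 3 gives a 1.6-fold higher number from compound 3 to compound 4 (0.20 log units; within the scatter) and so no change that can be told apart from the scatter of repeated measurements. This is a single readable step on a single core, so it sets no pattern and does not show that the change acts alike on the core of compound 1. The same change on that core cannot be read, because compound 1 and compound 2 each give a limit of the assay rather than a number: the limit of > 100000 nM in this assay, at which 2 of the 4 values shown sit.

On these data alone, how the read-out would respond to an amine or a carboxylic acid on that aromatic carbon stays open on both cores. As far as these compounds go, whether any group there could move the value of either core beyond the scatter also stays open.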